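From 4-bromophenyl to 2-fluorophenyl under an assay limit

The source may hold more compounds than are shown below. What is called first, only, known or untested is meant among the compounds shown, and "the series" means these compounds.

Compound 1 (`CNC(=O)c1ccccc1Oc1nc(Nc2ccc(Br)cc2)ncc1Br`) was examined in a functional assay on U-937 cells (Homo sapiens) for antiproliferative activity, read by MTT assay, with a stated time of 24 h; on this read-out lower numbers stand for stronger inhibition and higher numbers for weaker inhibition. In this assay compound 1 gives > 50000 nM, which is a limit and not a number. Compound 2 (`CNC(=O)c1ccccc1Oc1nc(Nc2ccc(C(F)(F)F)cc2)ncc1Br`) gives > 50000 nM, which is also a limit. Compound 1 thus has no measured number, and the data show (the limit of > 50000 nM in this assay, at which 2 of the 2 values shown sit). Among the compounds with values here, the only measured step is a step that the two limits leave unreadable from compound 1 to compound 2, so it supplies no size to carry forward.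

Compound 3 (`CNC(=O)c1ccccc1Oc1nc(Nc2ccccc2F)ncc1Br`) has not yet been measured. Its difference from compound 1 is 2-fluorophenyl in place of 4-bromophenyl on a nitrogen on an aromatic ring. Within the data shown here, no measured step covers this exchange directly. Among the measured compounds shown here, the expectation therefore rests on compound 1 at > 50000 nM, a limit, and no step of definite size or direction can be derived from it. Most likely the result will again be only a limit. The estimated change is a number no higher from compound 1 to compound 3 (the limit leaves the size open), with no gain beyond the scatter expected. For compound 3 the estimated value is 50000 nM, with an expected range from 20000 nM to 100000 nM.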

Compound 3, half-maximal inhibitory concentration: > 50000 nM
Compound 3: no number, only a limit; the forecaster's own chance of this, stated with the estimate: 85%; the middle value lies on the limit itself.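

In this assay compound 3 gives > 50000 nM, which is a limit and not a number. Compound 1 also has only a limit, so no step from compound 1 to compound 3 can be read, and the data show only this: the limit of > 50000 nM in this assay, at which 3 of the 3 values shown sit.

The compounds shown leave open how strongly any of them inhibits and whether any other group on this nitrogen would give a measurable value.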